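The compounds below may be only part of what the source reports. "The series", "measured", "known", "first", "only" and "open" are said of these compounds alone.

Working notes on the series.

Of the compounds shown here, two have been measured in a functional assay on DU-145 cells (Homo sapiens) for antiproliferative activity, read by MTT assay, with a stated time of 48 h; a lower number here means a stronger inhibitor, a higher number a weaker inhibitor. Compound 1, `COc1ccc(-n2cc(COC(=O)/C(C)=C/CC/C(C)=C/CC/C(C)=C/CC[C@@H]3[C@@]4(C)CCC(=O)C(C)(C)[C@H]4CC[C@@]3(C)O)nn2)cc1`, stands at the high end of the pair: in this assay compound 1 gives 135000 nM. Compound 2, `C/C(=C\CC/C(C)=C/CC[C@@H]1[C@@]2(C)CCC(=O)C(C)(C)[C@H]2CC[C@@]1(C)O)CC/C=C(\C)C(=O)OCc1cn([C@@H]2C[C@@H](n3cc(C)c(=O)[nH]c3=O)O[C@H]2CO)nn1`, is the nearer and only comparator; in this assay compound 2 gives 13800 nM, and the gap between the two is beyond the scatter. The two compounds differ in more than one place, so no single-point step can be read from them.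

Compound 3, `C/C(=C\CC/C(C)=C/CC[C@@H]1[C@@]2(C)CCC(=O)C(C)(C)[C@H]2CC[C@@]1(C)O)CC/C=C(\C)C(=O)OCc1cn(-c2cccc(O)c2)nn1`, is the next compound to be measured. It differs from compound 1 as follows: 3-hydroxyphenyl in place of 4-methoxyphenyl on an aromatic nitrogen. Both groups sit on an aromatic nitrogen of a five-membered aromatic ring with three nitrogens, so the change is confined to the aryl substituent there.

Among the measured compounds shown here, with no measured step of this kind to draw on, only a modest shift is expected from compound 1 to compound 3 in this assay, as a 1.5-fold lower number from compound 1 to compound 3 (0.18 log units; within the scatter), with a small improvement the more likely direction. Compound 3 is estimated at 90000 nM in this assay, with a range from 30000 nM to 250000 nM.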

Compound 3, half-maximal inhibitory concentration: 28400 nM
Estimate against measurement, compound 3: 3.2-fold (0.50 log units) above; the measured number lies below the stated range.
By their numbers in this assay, from the lowest: compound 2; then compound 3; then compound 1.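

This position is not silent: in this assay, the aryl substituent on the aromatic nitrogen of the five-membered aromatic ring with 3 nitrogen can move the read-out, with a 4.8-fold lower number from compound 1 to compound 3 (0.68 log units; beyond the scatter) while the shared core stays unchanged. Among the compounds shown here, the step is the first single-point reading and shows that 3-hydroxyphenyl gives a lower number than 4-methoxyphenyl, though the change is bundled: the substituent's ring position and its identity differ together, alongside the move from 8 heavy atoms and 0 hydrogen-bond donors to 7 heavy atoms and 1 hydrogen-bond donor. No measured evidence on the compounds bears on why the number falls, so this step gives only its size and direction.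

A 4-hydroxyphenyl or 3-methoxyphenyl group at the same nitrogen would be needed to separate the identity of the substituent from its ring position, and so to show which part of the change carries the step. Also open, as far as these compounds go, is how the read-out responds on this aryl ring to an amine or a carboxylic acid, or to replacing the aryl group with a longer alkyl chain.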